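Pyrazolyl to dimethyltriazolyl acetamide swap on shared core

The source may hold more compounds than are shown below. What is called first, only, known or untested is meant among the compounds shown, and "the series" means these compounds.

Three compounds of the series carry a measurement in a functional assay on CHO-K1 cells for antagonist activity at C-X-C chemokine receptor type 3 (Homo sapiens), read by FLIPR, with a stated time of 10 min, in the presence of a further agent that is not named here; a higher number here means a weaker inhibitor, a lower number a stronger inhibitor. Compound 1 `C[C@@H]1CN(c2sc(C(F)(F)F)nc2-c2nc3ccccc3[nH]2)CCN1C(=O)Cn1cccn1` gives 13 nM in this assay. Compound 2 `C[C@@H]1CN(c2sc(C(F)(F)F)nc2-c2nc3cc(Cl)ccc3[nH]2)CCN1C(=O)Cn1cnc2cccnc21` gives 2.8 nM in this assay, and compound 3 `Cc1nc(C)n(CC(=O)N2CCN(c3sc(C(F)(F)F)nc3-c3nc4ccc(C(C)(C)O)c(F)c4[nH]3)C[C@H]2C)n1` gives 9.4 nM in this assay. Compound 1 holds the highest number of the three: its gap to compound 3 lies within the usual scatter, while its gap to compound 2 lies beyond it. Going by the values given here, compound 2 and compound 3 differ from compound 1 in more than one place, so no single step between measured compounds can be read off.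

Compound 4 `Cc1nc(C)n(CC(=O)N2CCN(c3sc(C(F)(F)F)nc3-c3nc4ccccc4[nH]3)C[C@H]2C)n1` is not yet measured. It differs from compound 1 in one place: 3,5-dimethyl-1H-1,2,4-triazol-1-yl in place of 1H-pyrazol-1-yl on a saturated chain carbon bound to a carbonyl carbon. Compound 3 carries the same group on the amide chain, but also a differently substituted core, so its value of 9.4 nM only loosely informs the step. The step from compound 1 to compound 4 is expected to be small, a 1.4-fold lower number from compound 1 to compound 4 (0.16 log units; within the scatter), and not clearly beyond the scatter. Compound 4 is therefore estimated at 9 nM in this assay, with a range from 4 nM to 25 nM.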

Compound 4, half-maximal inhibitory concentration in the C-X-C chemokine receptor type 3 assay: 3.2 nM
Compound 4: the middle estimate sits 2.8-fold (0.45 log units) above what was measured; measured number outside the range, below it.
By their numbers in the C-X-C chemokine receptor type 3 assay, from the lowest: compounds 2 and 4 (each within the scatter of the next); then compounds 3 and 1 (each within the scatter of the next).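

Going by these compounds alone, this is the first single-place reading at this position, and it shows that the group on the saturated chain carbon bound to the carbonyl carbon matters on the shared core: in the C-X-C chemokine receptor type 3 assay compound 1 gives 13 nM and compound 4 gives 3.2 nM. In the C-X-C chemokine receptor type 3 assay the swap to 3,5-dimethyl-1H-1,2,4-triazol-1-yl gives a 4.1-fold lower number from compound 1 to compound 4 (0.61 log units; beyond the scatter). In a physicochemical assay for solubility, in simulated intestinal fluid (a higher number here means a more soluble compound, a lower number a less soluble compound), compound 1 gives 352 ug/mL and compound 4 gives 440 ug/mL. In the physicochemical assay the same swap gives a 1.3-fold higher number from compound 1 to compound 4 (0.10 log units; within the scatter), so the two compounds are not separated on that read-out. No measurement shown here accounts for the step in the C-X-C chemokine receptor type 3 assay.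

The compounds shown do not separate the added ring nitrogen from the two methyl groups; an unmethylated 1H-1,2,4-triazol-1-yl or a 3,5-dimethyl-1H-pyrazol-1-yl would do so. From the compounds shown here alone, whether the step carries over to cores bearing a chlorine or a 2-hydroxypropan-2-yl group also stays open.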